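This account rests on a few compounds, and the source may have more. Where it says the series, first, only, none or still open, it means among the compounds named here.

Measured compounds in a functional assay on MDA-MB-231 cells (Homo sapiens) for antiproliferative activity, with a stated time of 5 days; on this read-out higher numbers stand for weaker inhibition and lower numbers for stronger inhibition:
compound 1 `CC1OC2(C=CC(=O)C=C2)N(c2nc(-c3cccc4ccccc34)nn2-c2ccccc2)C1=O` gives 100 nM
compound 2 `CC1OC2(C=CC(=O)C=C2)N(c2nc(-c3ccc4ccccc4c3)nn2-c2ccc3ccccc3c2)C1=O` gives 60 nM
compound 3 `O=C1C=CC2(C=C1)OCC(=O)N2c1nc(-c2cccc3ccccc23)nn1-c1ccccc1` gives 50 nM

Compound 3 has the lowest number of the three in this assay, but its nearest neighbour is compound 2 at 60 nM, and the gap is within the scatter; the gap to compound 1 is also within the scatter, so no order among the three can be read from these numbers. Within the data shown here, the one single-point step recorded is a 2.0-fold lower number from compound 1 to compound 3 (0.30 log units; within the scatter), which concerns the saturated ring and not the aromatic groups.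

Compound 4 `O=C1C=CC2(C=C1)OCC(=O)N2c1nc(-c2ccc3ccccc3c2)nn1-c1ccccc1` is not yet measured. It differs from compound 3 in one place: naphthalen-2-yl in place of naphthalen-1-yl on an aromatic carbon. Among the measured compounds shown here, no measured pair isolates this change. Compound 2 carries naphthalen-2-yl at the same position but also has a naphthalen-2-yl in place of the phenyl group on the ring nitrogen, so its value of 60 nM can only be set beside that of compound 1, which gives 100 nM, without drawing a step from it; the two lie within the scatter of each other. On that basis the step of no change at the digits printed from compound 3 to compound 4 (within the scatter) is expected to stay within the scatter. Compound 4 is estimated at 50 nM in this assay, with a range of 20 nM to 130 nM.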

Compound 4, half-maximal inhibitory concentration: 70 nM
Compound 4: the middle estimate sits 1.4-fold (0.15 log units) below what was measured; the range from low to high includes it.
By their numbers in this assay, from the lowest: compounds 3, 2, 4 and 1 (each within the scatter of the next).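

The swap of naphthalen-1-yl for naphthalen-2-yl on the aromatic carbon of the five-membered aromatic ring now has a pair of its own in this assay, with a 1.4-fold higher number from compound 3 to compound 4 (0.15 log units; within the scatter), whereas before this position could only be viewed through compound 2, which differs in a second place as well. With the rest of the structure held constant, including the phenyl group on the ring nitrogen and the hydrogen on the saturated ring carbon, the two attachments of the naphthalene cannot be told apart in this read-out, so this change at this position has no readable effect on antiproliferative activity in this pair. No measured evidence bears on this result.

Among these compounds, whether the same holds with methyl on the saturated ring carbon, or with naphthalen-2-yl on the ring nitrogen, remains open, as no single-place pair tests the swap on those backgrounds. Also open, from the compounds shown here alone, is how far this position tolerates groups other than naphthalene, such as a pyridine ring, an amine or a carboxylic acid, as the two groups compared here have the same atoms and the same counted features.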